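The source may report more compounds than this note shows. Statements on the series, on what has been measured and on what is new or still open speak of the compounds shown alone.

Measured in an ADME assay on HeLa cells (Homo sapiens) for cytotoxicity, read by MTT assay; on this read-out higher numbers stand for weaker inhibition and lower numbers for stronger inhibition:
- compound 1 `COc1ccc(C[C@H]2COC(=O)[C@@H]2Cc2ccc(OCc3cn(Cc4ccc(Cl)cc4)nn3)c(OC)c2)cc1OC`: 242000 nM
- compound 2 `COc1ccc(C[C@H]2COC(=O)[C@@H]2Cc2ccc(OCC(=O)N3CCCCC3)c(OC)c2)cc1OC`: 293000 nM
- compound 3 `COc1ccc(C[C@H]2COC(=O)[C@@H]2Cc2ccc(OCC(=O)N3CCCC3)c(OC)c2)cc1OC`: >= 600000 nM

Compound 3 has no exact number and stands only at a limit of the assay, >= 600000 nM.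

Compound 4 `COc1ccc(C[C@H]2COC(=O)[C@@H]2Cc2ccc(OCc3cn(-c4ccccc4)nn3)c(OC)c2)cc1OC` has yet to be measured in this assay. In it, 1-phenyl-1H-1,2,3-triazol-4-yl replaces (pyrrolidin-1-yl)carbonyl on a saturated chain carbon bound to an oxygen on an aromatic ring (1-phenyl-1H-1,2,3-triazol-4-yl in place of (pyrrolidin-1-yl)carbonyl on a saturated chain carbon bound to an oxygen on an aromatic ring).

Among the compounds with values here, the one measured step, an at least 2.0-fold higher number from compound 2 to compound 3 (0.31 log units; beyond the scatter), changes only the amine part of the leaving group, so it bears on this change only indirectly. It does show that compound 3 lies at the weak end of this small set. The closer guide is compound 1, which also carries a five-membered aromatic ring with 3 hetero atoms and gives 242000 nM.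

A lower number is therefore expected, with an estimated step of an at least 2.4-fold lower number from compound 3 to compound 4 (0.38 log units; beyond the scatter). Compound 4 is expected at 250000 nM, with an estimated range from 100000 nM to 600000 nM.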

Compound 4, half-maximal inhibitory concentration: 124000 nM
Compound 4: middle estimate off by 2.0-fold (0.30 log units), on the high side; measured number inside the range.
By their numbers in this assay, from the lowest: compounds 4, 1 and 2 (each within the scatter of the next, the first and the last beyond it). At a limit, above all of these: compound 3.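

Within the data shown here, replacing (piperidin-1-yl)carbonyl with 1-phenyl-1H-1,2,3-triazol-4-yl on a saturated chain carbon bound to an oxygen on an aromatic ring gives, in this assay, a 2.4-fold lower number from compound 2 to compound 4 (0.37 log units; beyond the scatter), the first exact step at this place that swaps the carbonyl group for a triazole. Against (pyrrolidin-1-yl)carbonyl the step is an at least 4.8-fold lower number from compound 3 to compound 4 (0.68 log units; beyond the scatter), which is a bound and not an exact size, as compound 3 stands only at a limit: the limit of >= 600000 nM in this assay, at which 1 of the 4 values shown sits. The group on the aromatic nitrogen shows no readable effect, with a 2.0-fold lower number from compound 1 to compound 4 (0.29 log units; within the scatter), so phenyl and 4-chlorobenzyl cannot be told apart here.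

The compounds shown leave open whether a carboxylic acid or a methoxy group on the phenyl ring would shift the number. They also leave open how a dimethylamino group on the carbonyl would compare.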